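A few compounds are considered here, and "the series" means these few. Any claim that something is new, unique, unknown or untested is made for them only; others in the source may bear on it.

Compound 1 `O=C(O)c1ccc(Cl)c(-c2cccc(COc3ccc4c(c3)CN(C3CCCC3)C4=O)c2)c1` — 93.9%
Compound 2 `O=C(O)c1cc(F)cc(-c2cccc(COc3ccc4c(c3)CN(C3CCCC3)C4=O)c2)c1` — 80.8%

In an assay on HEK293 cells for positive allosteric modulation of metabotropic glutamate receptor 2 (Rattus norvegicus), read by thallium flux (on this read-out higher numbers stand for larger maximal responses and lower numbers for smaller maximal responses), compound 2 gives 80.8%, the lower of the two numbers. Compound 1 gives 93.9%. Among the compounds with values here, the one measured step is a number 13.1 percentage points lower from compound 1 to compound 2 (beyond the scatter), beyond the scatter. Compound 3 `O=C(O)c1ccc(-c2cccc(COc3ccc4c(c3)CN(C3CCCC3)C4=O)c2)c(Cl)c1` is not yet measured; it differs from compound 2 thus: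
4-carboxy-2-chlorophenyl in place of 3-carboxy-5-fluorophenyl on an aromatic carbon
That step bears on the change, since compound 1 and compound 3 both carry chlorine and the acid on the entering ring while compound 2 carries fluorine. A rise back toward compound 1 is therefore expected, modest in size: the expected step is a number 7.2 percentage points higher from compound 2 to compound 3 (within the scatter). Compound 3 is estimated at 88%, within 74% to 100%.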

Compound 3, largest response reached (reported as percent of maximum), in percent of the reference or control that the assay uses: 89.4%
Estimate against measurement, compound 3: 1.4 percentage points below; the range from low to high includes it.
By their numbers in this assay, from the lowest: compounds 2, 3 and 1 (each within the scatter of the next, the first and the last beyond it).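

In this assay, exchanging 5-carboxy-2-chlorophenyl for 4-carboxy-2-chlorophenyl gives a number 4.5 percentage points lower from compound 1 to compound 3 (within the scatter), so this change of the carboxylic acid's place on the chlorine-bearing ring is not resolved by this read-out. Exchanging 3-carboxy-5-fluorophenyl for 4-carboxy-2-chlorophenyl gives a number 8.6 percentage points higher from compound 2 to compound 3 (within the scatter), so compound 3 cannot be separated from compound 2 either, although compound 1 and compound 2 stand apart. Nothing available explains these numbers.

Going by these compounds, it remains open whether a tetrazole or a primary amide could stand in for the carboxylic acid at this position. A methyl group in place of the chlorine is likewise an open case.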